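Hydroxy in place of hydrogen: compound 3 toward compound 4

The source may hold more compounds than are shown below. What is called first, only, known or untested is meant among the compounds shown, and "the series" means these compounds.

Three compounds carry results so far. In a functional assay on cells (Mus musculus) for cytotoxicity, read by MTT assay, with a stated time of 72 h (a lower number here means a stronger inhibitor, a higher number a weaker inhibitor), compound 1 `COc1cc2c(cc1O)O[C@H](c1ccccc1)CC2=O` gives 5900 nM. Compound 2 `O=C1c2ccc(O)cc2O[C@H](c2ccccc2)[C@H]1O` reaches only a limit of this assay, > 100000 nM, which is the limit of > 100000 nM in this assay, at which 1 of the 3 values shown sits. Compound 3 `COc1ccc(-c2coc3cc(O)ccc3c2=O)c(O)c1` gives 49300 nM in this assay, the highest of the two numbers shown; compound 1 sits lower by a gap beyond the usual scatter.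

Compound 4 `COc1ccc(-c2coc3cc(O)cc(O)c3c2=O)c(O)c1` differs from compound 3 by hydroxy in place of hydrogen on an aromatic carbon. Within the data shown here, no pair among the measured compounds shows this change, so its size is uncertain. A modest step to a lower number is expected, around the edge of the scatter. Compound 4 is expected to give about 30000 nM in this assay, within 8000 nM to 100000 nM. The expected step is a 1.6-fold lower number from compound 3 to compound 4 (0.22 log units; within the scatter).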

Compound 4, half-maximal inhibitory concentration: 93600 nM
Compound 4: the middle estimate sits 3.1-fold (0.49 log units) below what was measured; the range from low to high includes it.
By their numbers in this assay, from the lowest: compound 1; then compounds 3 and 4 (each within the scatter of the next). At a limit, above all of these: compound 2.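

In this assay, hydroxy in place of hydrogen at this position gives a 1.9-fold higher number from compound 3 to compound 4 (0.28 log units; within the scatter). Among these compounds, this is the first direct reading of the change, and it shows that the added hydroxy does not shift the result beyond the scatter on this core. The values shown give no cause for this step.

Going by these compounds, whether an amine or a carboxylic acid at this position would move the number beyond the scatter remains open. So does the effect of the same hydroxy change on the core of compound 1.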